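Second hydroxymethyl on the smallest core

The source may hold more compounds than are shown below. What is called first, only, known or untested is meant among the compounds shown, and "the series" means these compounds.

The study compares three measured compounds in a functional assay on MCF7 cells (Homo sapiens) for cytotoxicity, read by MTT assay, with a stated time of 72 h; a higher number here means a weaker inhibitor, a lower number a stronger inhibitor. Compound 1 `Cc1c(CO)cc2n1[C@@H](c1ccccc1)SC2` gives 2400 nM, and compound 2 `Cc1cc(CO)c2n1[C@@H](c1ccccc1)SC2` gives 29900 nM. Compound 3 `Cc1c(CO)cc2n1CSC2` gives 192000 nM, the highest of the three numbers; it lies beyond the scatter from compound 2 and further still from compound 1, so on these numbers compound 3 is the weakest inhibitor of the set.

Compound 4 `Cc1c(CO)c(CO)c2n1CSC2` has not been measured. It differs from compound 3 in one place: hydroxymethyl in place of hydrogen on an aromatic carbon. Among the measured compounds shown here, no measured pair isolates this change, since the shift from compound 1 to compound 2 moves the hydroxymethyl rather than adding a second one, and both of those compounds carry a phenyl group that compound 3 and compound 4 lack.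

For the measured compounds named here, with no direct precedent, compound 4 is expected to stay near compound 3, with a step of a 1.3-fold lower number from compound 3 to compound 4 (0.11 log units; within the scatter) that is not clearly beyond the scatter. The estimate for compound 4 in this assay is 150000 nM, within a range of 50000 nM to 400000 nM.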

Compound 4, half-maximal inhibitory concentration: 22600 nM
The estimate for compound 4 lay 6.6-fold (0.82 log units) above the measured number; the whole stated range lies above it.
By their numbers in this assay, from the lowest: compound 1; then compounds 4 and 2 (each within the scatter of the next); then compound 3.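

Placing hydroxymethyl in place of hydrogen on this aromatic carbon, two ring bonds from the ring nitrogen, gives in this assay an 8.5-fold lower number from compound 3 to compound 4 (0.93 log units; beyond the scatter) on the core of compound 3, the first change in the series that can be read in one place. Among the compounds shown here, the position therefore accepts this group alongside the existing hydroxymethyl group, and here the addition goes with stronger inhibition, which no earlier pair could show. Nothing in the data accounts for this step.

The compounds shown leave open whether the same addition would have a comparable effect on a core carrying the phenyl group of compound 1. They also leave open how an amine, a carboxylic acid or a longer chain would behave on this carbon, and whether the hydroxyl oxygen of the hydroxymethyl group matters for the step.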